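This account rests on a few compounds, and the source may have more. Where it says the series, first, only, none or still open, it means among the compounds named here.

Three pyrazole chalcones have been examined in a functional assay on PC-3 cells (Homo sapiens) for cytotoxicity, read by sulforhodamine B assay, with a stated time of 48 h, tested at 0.1 uM; on this read-out lower numbers stand for a stronger effect and higher numbers for a weaker effect at the one concentration tested. Compound 1 `COc1ccc(-c2cc(/C=C/C(=O)c3ccc(OC)c(OC)c3)[nH]n2)cc1` gives 91%, compound 2 `COc1cc(-c2cc(/C=C/C(=O)c3ccc(Cl)c(Cl)c3)[nH]n2)cc(OC)c1OC` gives 100%, and compound 3 `COc1cc(C(=O)/C=C/c2cc(-c3cc(OC)c(OC)c(OC)c3)n[nH]2)cc(OC)c1OC` gives 92%. Compound 2 holds the highest of the three numbers, yet compound 3 and compound 1 both sit within the usual scatter of it, so the three readings cannot be told apart. Compound 4 `COc1cc(-c2cc(/C=C/C(=O)c3ccc(F)c(F)c3)[nH]n2)cc(OC)c1OC` has not been measured; it differs from compound 2 as follows: 3,4-difluorophenyl in place of 3,4-dichlorophenyl on a carbonyl carbon. Going by the values given here, no pair of measured compounds differs in just this one place, so no measured step guides the expectation. Given that all three measured values lie near full activity, compound 4 is expected to stay there, with a number 4 percentage points lower from compound 2 to compound 4 (within the scatter) as the anticipated step, amounting to nothing beyond the scatter. The estimate for compound 4 in this assay is 96%, within a range from 85% to 105%.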

Compound 4, a percentage reported as activity, at one concentration (the size of the read-out at that concentration, not a potency): 93%
Beside the measured number, compound 4's estimate is 3 percentage points above it; measured number inside the range.
By their numbers in this assay, from the lowest: compounds 1, 3, 4 and 2 (each within the scatter of the next).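

In this assay, going by these compounds alone, the change to 3,4-difluorophenyl in place of 3,4-dichlorophenyl on a carbonyl carbon gives the first comparison of compounds differing in one place, a number 7 percentage points lower from compound 2 to compound 4 (within the scatter). At this position, the two halogen-bearing rings therefore cannot be told apart on this read-out. No measured evidence bears on this result. On these data alone, it remains open whether an amine or a carboxylic acid at this place would give a reading beyond the scatter. A single concentration also leaves the potency of these compounds undefined.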